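The source may hold more compounds than are shown below. What is called first, only, known or untested is meant among the compounds shown, and "the series" means these compounds.

Compound 1 `COc1ccc2[nH]c(-c3ccccc3)c(C=C(C#N)C#N)c2c1` and compound 2 `COc1ccc(-c2[nH]c3ccc(OC)cc3c2C=C(C#N)C#N)cc1` share a core and differ in one place. In a functional assay on RPMI-8226 cells (Homo sapiens) for inhibition, read by sulforhodamine B assay, with a stated time of 48 h (a higher number here means a weaker inhibitor of growth, a lower number a stronger inhibitor of growth), compound 1 gives 2600 nM, and compound 2 gives 5100 nM. The change from compound 2 to compound 1 is hydrogen in place of methoxy on an aromatic carbon. It brings a 2.0-fold lower number from compound 2 to compound 1 (0.29 log units; within the scatter), so the two values cannot be told apart.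

Compound 3 `COc1ccc2[nH]c(-c3ccccc3)c(/C=C(\C#N)S(=O)(=O)c3ccccc3)c2c1` rests on another core; the difference between the core of compound 3 and the core of compound 2 is not broken down here. In this assay compound 3 is "not determined" (no result reported), so no number was reported for it. Compound 4 `N#C/C(=C\c1c(-c2ccccc2)[nH]c2ccccc12)S(=O)(=O)c1ccccc1` is reached from compound 3 by hydrogen in place of methoxy on an aromatic carbon. For the measured compounds named here, this is the same kind of change as the one from compound 2 to compound 1, but not the same: in compound 2 the methoxy leaves a six-membered aromatic ring of carbon only, para to a large group, whereas in compound 3 it leaves a six-membered aromatic ring of carbon only that is part of a fused or bridged system of two rings, meta to a fused ring and para to a fused ring.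

Going by the values given here, compound 3 has no number, so no measured step can be set beside the earlier one. Among the compounds with values here, the only measured guide to a change of this kind is a 2.0-fold lower number from compound 2 to compound 1 (0.29 log units; within the scatter), a step within the scatter; a similarly small step is expected for the change to compound 4, though its starting point is unknown and the expectation is accordingly wide. Compound 4 is expected to give about 3000 nM in this assay, between 500 nM and 20000 nM.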

Compound 4, concentration for 50% growth inhibition: 714 nM
Compound 4: middle estimate off by 4.2-fold (0.62 log units), on the high side; measured number inside the range.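

In this assay compound 4 gives 714 nM while compound 3 has no number, so no new step can be read from this pair. The compounds shown leave open what hydrogen in place of methoxy on the aromatic carbon of compound 3 does to growth inhibition. Nothing shown offers an explanation for the value of compound 4.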